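Swapping a Chlorophenyl for a Styryl Group

This account rests on a few compounds, and the source may have more. Where it says the series, first, only, none or still open, it means among the compounds named here.

Compound 2 `Cc1cc(O)c(C2=NN(c3ccc(S(N)(=O)=O)cc3)C(c3ccccc3Cl)C2)cc1Cl` is one of two measured compounds that share a core. Going by the values given here, in a functional assay on SK-MEL-5 cells (Homo sapiens) for antiproliferative activity, with a stated time of 48 h (on this read-out lower numbers stand for higher toxicity in this test and higher numbers for lower toxicity in this test), compound 2 gives 36000 nM, which stands lowest of the two numbers on paper, though only within the scatter of its sole neighbour. That neighbour is compound 1 `Cc1cc(O)c(C2=NN(c3ccc(S(N)(=O)=O)cc3)C(c3ccccc3O)C2)cc1Cl`, which in this assay gives 42700 nM. Among the compounds with values here, the only measured step, a 1.2-fold lower number from compound 1 to compound 2 (0.07 log units; within the scatter), took place on the same saturated ring carbon as the change considered now, but it traded one small group for another and moved nothing beyond the scatter. Compound 3 `Cc1cc(O)c(C2=NN(c3ccc(S(N)(=O)=O)cc3)C(/C=C/c3ccccc3)C2)cc1Cl` carries a larger change: 2-phenylethenyl in place of 2-chlorophenyl on a saturated ring carbon. Within the data shown here, no measured step shows what such a swap does here, so the expectation rests on the flat picture seen so far. The step expected from this change is a 1.1-fold higher number from compound 2 to compound 3 (0.02 log units; within the scatter). For compound 3 the expected value in this assay is 38000 nM, with a range from 15000 nM to 95000 nM.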

Compound 3, concentration lethal to 50% of the cells: 40500 nM
Compound 3: middle estimate off by 1.1-fold (0.03 log units), on the low side, and the stated range covers the measured number.
By their numbers in this assay, from the lowest: compounds 2, 3 and 1 (each within the scatter of the next).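

In this assay, 2-phenylethenyl on this saturated ring carbon gives a 1.1-fold higher number from compound 2 to compound 3 (0.05 log units; within the scatter) and, set against the 2-hydroxyphenyl group, gives a 1.1-fold lower number from compound 1 to compound 3 (0.02 log units; within the scatter) as well. The flat picture therefore extends beyond the earlier swap on a phenyl ring: a group with a double bond outside aromatic rings also stays within the scatter of both earlier compounds, so none of the three groups stands apart. No measurement at hand explains this flat result.

The three compounds leave open whether this carbon stays as flat with a group of another kind, such as an amine, a carboxylic acid or a longer chain ending in a phenyl ring. On these data alone, all three also keep the 4-sulfamoylphenyl group and the 5-chloro-2-hydroxy-4-methylphenyl group, so what changes at those places would do remains unknown.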